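The compounds below may be only part of what the source reports. "The series", "measured", "known", "first", "only" and "open" are said of these compounds alone.

The three measured compounds share one core and differ in the group on an aromatic nitrogen and in the amide. Compound 1 `COc1cc2c(C(=O)N3CCCCCC3)cn(C(C)C)c(=O)c2cc1OC` carries an isopropyl there; compound 2 `CCOc1ccc(-n2cc(C(=O)N3CCC(F)CC3)c3cc(OC)c(OC)cc3c2=O)cc1` carries a 4-ethoxyphenyl, and compound 3 `CCN1CCc2ccc(-n3cc(C(=O)N4CCCCCC4)c4cc(OC)c(OC)cc4c3=O)cc21` carries a 1-ethyl-2,3-dihydro-1H-indol-6-yl. In an assay on CHO cells for antagonist activity at lysophosphatidic acid receptor 5 (Rattus norvegicus), read by cAMP accumulation, with a stated time of 30 min (on this read-out higher numbers stand for weaker inhibition and lower numbers for stronger inhibition), compound 1 gives > 30000 nM, which is a limit of the assay and not a number (the limit of > 30000 nM in this assay, at which 1 of the 3 values shown sits). In this assay compound 2 gives 750 nM. In this assay compound 3 gives 110 nM. Compound 1 therefore stands at the weak end of the numbers shown, with only a limit to its name.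

Compound 4 `COc1cc2c(C(=O)N3CCCCCC3)cn(-c3ccc(F)cc3)c(=O)c2cc1OC` differs from compound 1 by 4-fluorophenyl in place of isopropyl on an aromatic nitrogen. Among the compounds with values here, the one measured step that changes a single place is an at least 270-fold lower number from compound 1 to compound 3 (2.43 log units; beyond the scatter), and it is the step that bears on this change, since both replace the isopropyl with an aromatic group at the same nitrogen. Compound 2 cannot be put on a single-place step from compound 1, yet its value also sits far from the limit shown for compound 1. Because an at least 270-fold lower number from compound 1 to compound 3 (2.43 log units; beyond the scatter) was large, compound 4 is expected to show a large fall as well, the expected step being an at least 60-fold lower number from compound 1 to compound 4 (1.77 log units; beyond the scatter). Compound 4 is estimated at 500 nM, within a range from 150 nM to 3000 nM.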

Compound 4, half-maximal inhibitory concentration: > 3000 nM
Compound 4 ended at the assay's limit; the forecaster's own chance of this, stated with the estimate: 10%; at least 6.0-fold (0.77 log units) between middle value and limit.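

Compound 4 gives > 3000 nM in this assay, which is a limit of the assay and not a number, and compound 1 also ends at a limit, so the step between these two cannot be read: the limit of > 3000 nM in this assay, at which 1 of the 4 values shown sits.

The readable comparison is with compound 3, which has the same amide and the same core, and it gives an at least 27-fold higher number from compound 3 to compound 4 (1.43 log units; beyond the scatter). The large gain in inhibition seen with compound 3 therefore does not come with every aromatic group on this nitrogen, since among compounds 1, 3 and 4 only the 1-ethyl-2,3-dihydro-1H-indol-6-yl gives a measured number, whereas the 4-fluorophenyl does not.

Compound 2 carries a 4-ethoxyphenyl but also a different amide, so the compounds shown leave open how a 4-ethoxyphenyl would behave alongside the azepan-1-yl carbonyl group of compound 4. They also leave open whether a phenyl ring with a dimethylamino group or a morpholine in place of the fluorine would bring back a readable value, and how far compound 4 itself lies past its limit.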